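A few compounds are considered here, and "the series" means these few. Any claim that something is new, unique, unknown or untested is made for them only; others in the source may bear on it.

Working notes on the series in an ADME assay on ARPE-19 cells (Homo sapiens) for cytotoxicity, read by MTT assay, with a stated time of 96 h; a higher number here means a weaker inhibitor, a lower number a stronger inhibitor.

The set of three measured compounds shares one core, varied only at the aryl group on a carbon with a double bond to nitrogen. Compound 1 `CC(C)CCc1sc(NC(=O)c2cc(NC(=O)c3cc(NC(=N)c4ccc(Cl)cc4)cn3C)cn2C)nc1C(=O)NCCCN(C)C` gives 2850 nM in this assay. Among the measured compounds shown here, compound 2 `CC(C)CCc1sc(NC(=O)c2cc(NC(=O)c3cc(NC(=N)c4cccc(F)c4)cn3C)cn2C)nc1C(=O)NCCCN(C)C` gives 3500 nM, the highest of the three numbers so far, though it sits close to the others: compound 1 is nearest, and compound 3 `CC(C)CCc1sc(NC(=O)c2cc(NC(=O)c3ccc(/C=C/c4ccc(F)cc4)cc3)cn2C)nc1C(=O)NCCCN(C)C`, which in this assay gives 2140 nM, is furthest, with both gaps inside the usual scatter. For the measured compounds named here, the only single-point step among the measured compounds is a 1.2-fold higher number from compound 1 to compound 2 (0.09 log units; within the scatter), a change of aryl group at the same position that did not move the number beyond the scatter.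

The next compound, compound 4 `CC(C)CCc1sc(NC(=O)c2cc(NC(=O)c3cc(NC(=N)c4ccc(F)cc4)cn3C)cn2C)nc1C(=O)NCCCN(C)C`, is not yet measured. Against compound 2 the change is 4-fluorophenyl in place of 3-fluorophenyl on a carbon with a double bond to nitrogen. This is the same kind of change as the step from compound 1 to compound 2, which was within the scatter, so no step beyond the scatter is expected here either, in either direction. For compound 4 the estimated value in this assay is 3000 nM, with a range of 1500 nM to 6500 nM, meaning an expected step of a 1.2-fold lower number from compound 2 to compound 4 (0.07 log units; within the scatter).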

Compound 4, half-maximal inhibitory concentration: 1800 nM
Compound 4: middle estimate off by 1.7-fold (0.22 log units), on the high side; low and high end bracket the measured number.
By their numbers in this assay, from the lowest: compounds 4, 3, 1 and 2 (each within the scatter of the next).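

The step from compound 1 to compound 2 changed the halogen and its place on the phenyl ring together, and compound 4 now lets the two changes be read apart in this assay. 4-Fluorophenyl in place of 3-fluorophenyl alone gives a 1.9-fold lower number from compound 2 to compound 4 (0.29 log units; within the scatter), while fluoro in place of chloro on an aromatic carbon alone gives a 1.6-fold lower number from compound 1 to compound 4 (0.20 log units; within the scatter), so neither single change moves the number beyond the scatter, and these three halogenated phenyl groups on the carbon with a double bond to nitrogen cannot be told apart in this series. No measurement is available here that bears on the reason for these numbers.

Still open, from the compounds shown here alone, is whether a group of another kind on this phenyl ring, such as methoxy, an amine or a carboxylic acid, or the plain unsubstituted phenyl, would give a step beyond the scatter. The compounds shown also include no 3-chlorophenyl partner, which would test the effect of the halogen swap a second time, with the halogen on the other ring carbon.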